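Acetyl for bromo: the step from compound 1 to compound 4

The source may report more compounds than this note shows. Statements on the series, on what has been measured and on what is new or still open speak of the compounds shown alone.

Compound 1 `O=C(CSc1nc2cccnc2[nH]1)Nc1cccc(Br)c1` gives 23% in an assay on isolated protein for inhibition of Ectonucleotide pyrophosphatase/phosphodiesterase family member 1 (Homo sapiens), tested at 10 uM (a lower number here means less inhibition, a higher number more inhibition at the concentration tested (going by the name of the read-out)), the second highest of the three numbers measured. Compound 3 `O=C(CSc1nc2cccnc2[nH]1)Nc1ccccc1Cl` gives 19% in this assay; the step of a number 4 percentage points lower from compound 1 to compound 3 (within the scatter) lies within the scatter. Compound 2 `COc1ccc(NC(=O)CSc2ncc[nH]2)cc1OC`, built on a different core, gives 64%, beyond the scatter from compound 1. Compound 4 `CC(=O)c1cccc(NC(=O)CSc2nc3cccnc3[nH]2)c1` differs from compound 1 by acetyl in place of bromo on an aromatic carbon. Within the data shown here, the only measured step on the shared core, a number 4 percentage points lower from compound 1 to compound 3 (within the scatter), concerns a halogen swap on the amide-type nitrogen substituent and does not bear on an acetyl entering. Among the measured compounds shown here, with no relevant step measured, no change beyond the scatter is expected; the estimated step is a number 1 percentage points lower from compound 1 to compound 4 (within the scatter). Compound 4 is expected at 22%, with a range from 5% to 42%.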

Compound 4, a percentage reported as inhibition, at one concentration (the size of the read-out at that concentration, not a potency): 50%
For compound 4 the middle estimate is 28 percentage points below the measured one, and the stated range ends below it.
By their numbers in this assay, from the lowest: compounds 3 and 1 (each within the scatter of the next); then compound 4; then compound 2.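

In this assay, the aromatic carbon meta to a large group proves sensitive to what it carries: acetyl in place of bromo gives a number 27 percentage points higher from compound 1 to compound 4 (beyond the scatter). Among these compounds, this is the first step on the shared core that lies beyond the scatter, whereas the halogen swap gave only a number 4 percentage points lower from compound 1 to compound 3 (within the scatter). Nothing measured here explains the rise.

Still open, on these data alone, is whether the carbonyl alone accounts for the step or the larger acetyl group as a whole is needed. A carboxylic acid, an amine or a longer chain on the same carbon could separate these readings.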